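The source may report more compounds than this note shows. Statements on the series, on what has been measured and on what is new or still open speak of the compounds shown alone.

Working notes on the series, read in a functional assay on Caco-2 cells (Homo sapiens) for cytotoxicity, read by MTT assay, with a stated time of 48 h; a higher number here means a weaker inhibitor, a lower number a stronger inhibitor. Compound 2 `O=C(/C=C(/C=C/c1ccc(O)cc1)NCCCO)/C=C/c1ccc(O)cc1` gives 31600 nM, the lower of the two actual numbers, and compound 1 `COc1cc(/C=C/C(=O)/C=C(/C=C/c2ccc(O)c(OC)c2)NCCO)ccc1O` gives 87200 nM, a gap beyond the scatter. Compound 3 `COCCNC(=C\C(=O)/C=C/c1ccc(O)c(OC)c1)/C=C/c1ccc(O)c(OC)c1` gives > 100000 nM, which is a limit of the assay and not a number.

The next entry is compound 4 `O=C(/C=C(/C=C/c1ccc(O)cc1)NCCO)/C=C/c1ccc(O)cc1`, reached from compound 2 by hydroxy in place of hydroxymethyl on a saturated chain carbon, two bonds along the chain from an amine nitrogen, or 3-hydroxypropyl to 2-hydroxyethyl.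

Among the compounds with values here, only one measured step touches this chain: an at least 1.1-fold higher number from compound 1 to compound 3 (0.05 log units; that floor lies within the scatter). It is a methyl in place of hydrogen on an oxygen on a saturated carbon, not a change of chain length, and it gives a floor rather than a size, so it sets no firm figure for the present change.

A small move to a higher number in this assay is still expected, because compound 1 carries the same (2-hydroxyethyl)amino group and gives 87200 nM, although its core differs from that of compound 4.

The expected size is a 1.6-fold higher number from compound 2 to compound 4 (0.20 log units; within the scatter), which may not clear the scatter. Compound 4 is estimated at 50000 nM, with an expected range of 20000 nM to 100000 nM.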

Compound 4, half-maximal inhibitory concentration: 57900 nM
Estimate against measurement, compound 4: 1.2-fold (0.06 log units) below; the range from low to high includes it.
By their numbers in this assay, from the lowest: compounds 2, 4 and 1 (each within the scatter of the next, the first and the last beyond it). At a limit, above all of these: compound 3.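

In this assay, within the data shown here, the change from 3-hydroxypropyl to 2-hydroxyethyl gives a 1.8-fold higher number from compound 2 to compound 4 (0.26 log units; within the scatter), the only step on this chain with a number at both ends. On the shared core of these two compounds, hydroxy in place of hydroxymethyl at this position therefore leaves no shift that can be told from the scatter, so the two chain lengths cannot be ranked here. The earlier step on this chain, an at least 1.1-fold higher number from compound 1 to compound 3 (0.05 log units; that floor lies within the scatter), concerns a different change and gives only a floor, and compound 3 remains a limit and not a number: the limit of > 100000 nM in this assay, at which 1 of the 4 values shown sits.

Going by these compounds, only these two chain lengths can be compared directly, so the effect of a longer chain such as 4-hydroxybutyl on this core remains open, as does that of a plain propyl chain without the terminal hydroxy. Also open, on these data alone, is whether an amine or a carboxylic acid at the chain end would give a step beyond the scatter, and whether methyl on the terminal oxygen would give a measurable step on the core of compound 4.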